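Cytotoxicity Outlook After One Aromatic Swap

The source may hold more compounds than are shown below. What is called first, only, known or untested is meant among the compounds shown, and "the series" means these compounds.

Three amides sharing one core were tested in an ADME assay on PC-3 cells (Homo sapiens) for cytotoxicity, read by WST assay, tested at 100 uM; on this read-out lower numbers stand for less inhibition and higher numbers for more inhibition at the one concentration tested (going by the name of the read-out). Compound 1 `O=C(Nc1cccc(Oc2nccc(C(F)(F)F)c2Cl)c1)C1CCCN(C(=O)c2cc(C(F)(F)F)cc(C(F)(F)F)c2)C1` shows 0% in this assay. Compound 2 `COc1cccc(C(=O)N2CCCC(C(=O)Nc3ccc(Cl)cc3)C2)c1` gives 0%, the same reading as compound 1 at the digits reported, and compound 3 `O=C(Nc1ccc(Cl)cc1)C1CCCN(C(=O)c2ccc(-c3ccco3)cc2)C1` gives 6%, a reading that lies within the usual scatter of both. None of the three compounds, then, registers a cytotoxic effect that can be told apart from noise at the single concentration used.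

Compound 4 `O=C(Nc1cccc(-c2ccco2)c1)C1CCCN(C(=O)c2cc(C(F)(F)F)cc(C(F)(F)F)c2)C1` has not yet been measured. It differs from compound 1 in one place: furan-2-yl in place of (3-chloro-4-(trifluoromethyl)pyridin-2-yl)oxy on an aromatic carbon. Among the measured compounds shown here, no measured pair in this set isolates exactly this change, so its effect can only be inferred. Compound 3 already carries a furan-2-yl on its core and reads 6%, so a large shift is not anticipated. The step from compound 1 to compound 4 in this assay is expected to be a number 3 percentage points higher from compound 1 to compound 4 (within the scatter), that is, no change beyond the scatter. Compound 4 is therefore estimated to give 3% in this assay, with a likely range from 0% to 15%.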

Compound 4, a percentage reported as inhibition, at one concentration (the size of the read-out at that concentration, not a potency): 0%
For compound 4 the middle estimate is 3 percentage points above the measured one, and the stated range covers the measured number.
By their numbers in this assay, from the lowest: compounds 1, 2, 4 and 3 (each within the scatter of the next).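

In this assay, among the compounds shown here, placing furan-2-yl where the (3-chloro-4-(trifluoromethyl)pyridin-2-yl)oxy group stood gives no change at the digits printed from compound 1 to compound 4 (within the scatter) and provides the first direct comparison at this position. The substituent on this aromatic carbon can therefore shrink from a six-membered aromatic ring group of 12 heavy atoms to a five-membered aromatic ring of 5 heavy atoms without the reading moving beyond the scatter. Neither compound gives a reading that stands out from the noise. For the compounds shown here, the step shows only that this swap adds no detectable cytotoxicity at the one concentration tested, not that the two groups are alike in other ways. The data offer no measured explanation for the result.

From the compounds shown here alone, it remains open whether a primary amine or a carboxylic acid on the same aromatic carbon would also leave the reading within the scatter. A longer chain, such as a butoxy group, could be tested in the same way to show whether any group at this position can raise the reading beyond the scatter.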